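This account rests on a few compounds, and the source may have more. Where it says the series, first, only, none or still open, it means among the compounds named here.

Compound 2 `C[C@@H]1CN([C@@H](C)CO)C(=O)c2cccc(NC(=O)Nc3cncc4ccccc34)c2O[C@H]1CN(C)S(=O)(=O)c1ccc2c(c1)OCCO2` gives the higher of the two numbers measured in a physicochemical assay for solubility, read by HPLC, in phosphate buffer, measured as thermodynamic solubility, with a stated time of 24 h, at pH 7.4 (a higher number here means a more soluble compound, a lower number a less soluble compound), where compound 2 gives 84900 nM. For the measured compounds named here, its nearest neighbour is compound 1 `C[C@@H]1CN([C@@H](C)CO)C(=O)c2cccc(NC(=O)Nc3nccc4ccccc34)c2O[C@H]1CN(C)S(=O)(=O)c1ccc2c(c1)OCCO2`, which in this assay gives 700 nM; the one measured step, a 120-fold higher number from compound 1 to compound 2 (2.08 log units; beyond the scatter), is large. Compound 3 `C[C@@H]1CN([C@@H](C)CO)C(=O)c2cccc(NC(=O)Nc3cccc4cnccc34)c2O[C@H]1CN(C)S(=O)(=O)c1ccc2c(c1)OCCO2` carries the change (isoquinolin-5-yl in place of isoquinolin-4-yl on an amide-type nitrogen). Going by the values given here, the only step on record moves a different pair of ring attachments, so it bears on this step only by showing how strongly the attachment point of the isoquinoline can move the solubility. Among the compounds with values here, since compound 3 shares with compound 2 an attachment that is not the one seen in compound 1, the expected step of a 3.4-fold lower number from compound 2 to compound 3 (0.53 log units; beyond the scatter) is a modest decrease that may fall within the scatter. Compound 3 is therefore estimated at 25000 nM, with a range from 4000 nM to 110000 nM.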

Compound 3, solubility: 60500 nM
Compound 3: middle estimate off by 2.4-fold (0.38 log units), on the low side; low and high end bracket the measured number.
By their numbers in this assay, from the lowest: compound 1; then compounds 3 and 2 (each within the scatter of the next).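

In this assay swapping isoquinolin-4-yl for isoquinolin-5-yl on the amide-type nitrogen gives a 1.4-fold lower number from compound 2 to compound 3 (0.15 log units; within the scatter) and so does not separate these two attachments. The large gap seen earlier is thus not tied to isoquinolin-4-yl alone, since an 86-fold higher number from compound 1 to compound 3 (1.94 log units; beyond the scatter) is of similar size. Among these three compounds, isoquinolin-1-yl is the attachment that stands apart, with compound 1 alone at the low end.

In this assay, from the compounds shown here alone, it remains open how an amine or a carboxylic acid on the isoquinolin-5-yl group, or a quinolin-4-yl group in its place, would read. No measurement shown here accounts for why isoquinolin-1-yl stands apart from the other two attachments.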